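A few compounds are considered here, and "the series" means these few. Any claim that something is new, unique, unknown or untested is made for them only; others in the source may bear on it.

The three compounds examined so far were tested in an in vitro assay on B300-19 cells for displacement of a labelled ligand from C-C chemokine receptor type 4 (Homo sapiens), tested at 1 uM; a higher number here means more inhibition at the concentration tested (going by the name of the read-out), a lower number less inhibition. Compound 1, `COc1cc2nc(NCc3ccccc3)nc(NC3CCCCCC3)c2cc1OC`, returned a reading of < 0%, which is a limit of the assay rather than a number. Compound 2, `c1ccc2c(NC3CCCCCC3)nc(N3CCC(N4CCCC4)CC3)nc2c1`, gave 0%. Compound 3, `COc1cc2nc(N3CCC(N4CCCC4)CC3)nc(N(C)C)c2cc1OC`, returned < 0%, again a limit of the assay and not a number. So compound 3 stands at the floor of what the assay can report, and it is not alone there, since (the limit of < 0% in this assay, at which 2 of the 3 values shown sit). With every reading sitting at the floor, none of the three compounds can be told apart from the others within the usual scatter, and the number of none of them can be called higher or lower than that of another.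

Compound 4, `CCNc1nc(N2CCC(N3CCCC3)CC2)nc2cc(OC)c(OC)cc12`, has not yet been measured. It differs from compound 3 in one place: ethylamino in place of dimethylamino on an aromatic carbon. Among the compounds with values here, no measured pair in this set shows what such a swap does, so the expectation rests on the flat picture of the three readings. Compound 3 shows no inhibition that the assay can register, and a small change of this kind is not expected to lift compound 4 beyond the scatter in this assay. The expected change is a number at least 2 percentage points higher from compound 3 to compound 4 (that floor lies within the scatter), nothing beyond the scatter. Compound 4 is therefore estimated at 2%, with a range from -10% to 15%.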

Compound 4, a percentage reported as inhibition, at one concentration (the size of the read-out at that concentration, not a potency): < 0%
Compound 4 gave a limit, no number; the forecaster's own chance of this, stated with the estimate: 50%; middle value at least 2 percentage points away from the limit.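

Compound 3 and compound 4 each gave a limit rather than a number, so no step can be read between them, and the swap of dimethylamino for ethylamino has no measurable size here. Both sit at the same floor: the limit of < 0% in this assay, at which 3 of the 4 values shown sit.

The compounds shown leave open which change, if any, would lift a reading clear of that floor in this assay.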